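The source may hold more compounds than are shown below. What is called first, only, known or untested is meant among the compounds shown, and "the series" means these compounds.

Measured compounds:
compound 1 `CNCC1Cc2cc(F)cc(-c3c(Cl)cccc3Cl)c2O1` — in an assay on CHO cells for inhibition of aquaporin-1 (Homo sapiens), read by FLIPR, with a stated time of 10 min (a lower number here means a stronger inhibitor, a higher number a weaker inhibitor), compound 1 gives 29400 nM
compound 2 `CNCC1Cc2cc(F)cc(-c3ccc(Cl)cc3Cl)c2O1` — in this assay compound 2 gives 9800 nM

Going by the values given here, compound 2 stands at the lowest of the two numbers so far; its nearest neighbour is compound 1, whose higher number lies beyond the usual scatter. Among the compounds with values here, the two differ in the substitution pattern of the pendant chlorinated ring, but no single-point step between them is counted here, so only their two values are on record.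

Compound 3 `NCC1Cc2cc(F)cc(-c3ccc(Cl)cc3Cl)c2O1` is the next member. It differs from compound 2 by one change: hydrogen in place of methyl on an amine nitrogen. Within the data shown here, no measured pair in this set shows the same change, so there is no counted step to lean on. For a change of this kind, at the amine end of the chain rather than on the aryl part, the expectation is a small step in this assay, within the scatter or at most a slight weakening. The step from compound 2 to compound 3 is expected to be a 1.3-fold higher number from compound 2 to compound 3 (0.12 log units; within the scatter). Compound 3 is accordingly estimated at 13000 nM, with a range from 4500 nM to 40000 nM.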

Compound 3, half-maximal inhibitory concentration: 15200 nM
For compound 3 the middle estimate is 1.2-fold (0.07 log units) below the measured one, within the range that was stated.
By their numbers in this assay, from the lowest: compounds 2, 3 and 1 (each within the scatter of the next, the first and the last beyond it).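

In this assay, going by these compounds alone, the step at the amine nitrogen gives a 1.6-fold higher number from compound 2 to compound 3 (0.19 log units; within the scatter), the first reading for this position. With the aryl part of compound 2 held fixed, the methylamino and amino forms cannot be told apart, so the methyl on this nitrogen is not required for the level of inhibition seen with that aryl part. No measured information here bears on the reason for this result.

Open, as far as these compounds go, is how a larger group on this nitrogen, such as ethyl or cyclopropyl, or a second methyl giving a dimethylamino group, would read in this assay. Also open, from the compounds shown here alone, is whether hydrogen in place of methyl on this nitrogen gives a similar step with the aryl part of compound 1, since one pair cannot show whether the step carries over.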